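Swapping Methyl for Methoxy on an Aromatic Carbon

The source may hold more compounds than are shown below. What is called first, only, known or untested is meant among the compounds shown, and "the series" means these compounds.

In a functional assay on HeLa cells (Homo sapiens) for antiproliferative activity, with a stated time of 48 h (a lower number here means a stronger inhibitor, a higher number a weaker inhibitor), compound 1 (`C=C(Br)C(=O)Nc1ccc(/C=C/C(=O)c2ccccc2)cc1`) gives 3900 nM, compound 2 (`C=C(Br)C(=O)Nc1ccc(/C=C/C(=O)c2ccc(F)cc2)cc1`) gives 1400 nM and compound 3 (`C=C(Br)C(=O)Nc1ccc(/C=C/C(=O)c2ccc(C)cc2)cc1`) gives 2100 nM. Compound 3 thus lies within the scatter of both compound 1 and compound 2. Compound 4 (`C=C(Br)C(=O)Nc1ccc(/C=C/C(=O)c2ccc(OC)cc2)cc1`) carries methoxy in place of methyl on an aromatic carbon. Three measured steps at this place bear on the change. Fluoro in place of hydrogen gave a 2.8-fold lower number from compound 1 to compound 2 (0.44 log units; beyond the scatter), methyl in place of hydrogen gave a 1.9-fold lower number from compound 1 to compound 3 (0.27 log units; within the scatter), and methyl in place of fluoro gave a 1.5-fold higher number from compound 2 to compound 3 (0.18 log units; within the scatter). With steps this size, no shift beyond the scatter is expected in this assay. The expected step is a 1.1-fold lower number from compound 3 to compound 4 (0.02 log units; within the scatter). For compound 4 the estimated value is 2000 nM, with an expected range of 900 nM to 4500 nM.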

Compound 4, half-maximal inhibitory concentration: 1400 nM
The estimate for compound 4 lay 1.4-fold (0.15 log units) above the measured number; the range from low to high includes it.
By their numbers in this assay, from the lowest: compounds 2, 4, 3 and 1 (each within the scatter of the next, the first and the last beyond it).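

Methoxy is the second group at this position, after fluoro, to clear the scatter against the hydrogen of the parent, with a 2.8-fold lower number from compound 1 to compound 4 (0.44 log units; beyond the scatter) in this assay. Among the substituted compounds the change cannot be told apart from noise: a 1.5-fold lower number from compound 3 to compound 4 (0.18 log units; within the scatter), and no change at the digits printed from compound 2 to compound 4 (within the scatter). No measurement at hand offers a reason for this result.

On these data alone, whether an amine or a carboxylic acid at this position would match these numbers stays open, as does whether a longer chain, such as ethoxy, would behave like methoxy.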